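The source may hold more compounds than are shown below. What is called first, only, known or untested is meant among the compounds shown, and "the series" means these compounds.

Compound 1 `Cc1nc(C(NC(=O)C(=O)Nc2ccc(Cl)c(F)c2)C2CCCCN2)sc1CO`: 77800 nM
Compound 2 `CC(=O)c1ccc(NC(=O)C(=O)NC(c2nc(C)c(CO)s2)C2CCCCN2)cc1`: > 107000 nM

In an ADME assay on MT2 cells (Homo sapiens) for cytotoxicity, read by XTT assay, with a stated time of 4 days (on this read-out lower numbers stand for higher toxicity in this test and higher numbers for lower toxicity in this test), compound 2 gives no number, only the limit > 107000 nM.

Compound 3 `Cc1nc(C(NC(=O)C(=O)Nc2ccc(F)cc2F)C2CCCCN2)sc1CO` has 2,4-difluorophenyl in place of 4-acetylphenyl on an amide-type nitrogen.

Among the measured compounds shown here, the one measured step at this place is an at least 1.3-fold higher number from compound 1 to compound 2 (0.13 log units; that floor lies within the scatter), and its size is known only as a floor. Compound 1, with its 4-chloro-3-fluorophenyl, gives 77800 nM, so a result for compound 3 in that region is expected, and no step beyond the scatter is expected. The expected step is an at least 1.1-fold lower number from compound 2 to compound 3 (0.07 log units; that floor lies within the scatter). For compound 3 the estimated value is 90000 nM, with an expected range of 45000 nM to 150000 nM.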

Compound 3, half-maximal cytotoxic concentration: > 110000 nM
Compound 3 gave a limit, no number; the forecaster's own chance of this, stated with the estimate: 40%; middle value at least 1.2-fold (0.08 log units) from the limit.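

In this assay, compound 3 gives the limit > 110000 nM, which is not a number. 2,4-Difluorophenyl thus joins 4-acetylphenyl in reading only as a limit, so two quite different aryl groups on this amide-type nitrogen give no measurable value. Against 4-chloro-3-fluorophenyl the change reads as an at least 1.4-fold higher number from compound 1 to compound 3 (0.15 log units; that floor lies within the scatter), while the step between the two limits cannot be read.

Open, as far as these compounds go, is whether a longer alkyl chain, or a phenyl carrying an amine or a carboxylic acid, on this nitrogen would move the number beyond the scatter.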